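The source may report more compounds than this note shows. Statements on the series, on what has been measured and on what is new or still open speak of the compounds shown alone.

Working notes on the series. In an assay on isolated protein for displacement of a labelled ligand from melanin-concentrating hormone receptor 1 (Homo sapiens) (a higher number here means a weaker inhibitor, a lower number a stronger inhibitor), compound 1 `CC1CCCN1c1ccc2cc(NC(=O)CCc3ccc(C(F)(F)F)cc3)ccc2n1` gives 5 nM, the lowest number of the three. Compound 2 `O=C(CCc1ccc(C(F)(F)F)cc1)Nc1ccc2nc(N3CCCCCC3)ccc2c1` gives 36 nM. Compound 3 `O=C(CCc1ccc(C(F)(F)F)cc1)Nc1ccc2nc(N3CCCCC3)ccc2c1` gives 12 nM, which is the second highest of the three numbers: its nearest neighbour is compound 1 and its furthest is compound 2. The three measured steps all exchange the saturated ring on the same aromatic carbon of the shared core and all are modest: a 2.4-fold higher number from compound 1 to compound 3 (0.38 log units; beyond the scatter), a 3.0-fold lower number from compound 2 to compound 3 (0.48 log units; beyond the scatter), and a 7.2-fold higher number from compound 1 to compound 2 (0.86 log units; beyond the scatter).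

Compound 4 `CNC(=O)NC1CCN(c2ccc3cc(NC(=O)CCc4ccc(C(F)(F)F)cc4)ccc3n2)C1` is the next one to be measured in this assay. Relative to compound 3 the change is 3-((methylcarbamoyl)amino)pyrrolidin-1-yl in place of piperidin-1-yl on an aromatic carbon. The measured steps bear on it only in part: they show that ring size and a methyl on the ring move this assay by modest amounts, but none of them introduces a urea or any hydrogen-bond donor on the saturated ring, so the added group is outside the tested ground. A modest step is expected, most likely toward a higher number, given that compound 3 already sits at 12 nM and that the largest measured change was a 7.2-fold higher number from compound 1 to compound 2 (0.86 log units; beyond the scatter). For compound 4 the expected value in this assay is 30 nM, with a range from 6 nM to 150 nM, corresponding to a 2.5-fold higher number from compound 3 to compound 4 (0.40 log units; beyond the scatter).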

Compound 4, half-maximal inhibitory concentration: 6 nM
Estimate against measurement, compound 4: 5.0-fold (0.70 log units) above; the range from low to high includes it.
By their numbers in this assay, from the lowest: compounds 1, 4 and 3 (each within the scatter of the next, the first and the last beyond it); then compound 2.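

In this assay, this position accepts 3-((methylcarbamoyl)amino)pyrrolidin-1-yl, which brings hydrogen-bond donors that piperidin-1-yl lacks, and the number stays close to both nearest neighbours: a 2.0-fold lower number from compound 3 to compound 4 (0.30 log units; within the scatter), and a 1.2-fold higher number from compound 1 to compound 4 (0.08 log units; within the scatter). Going by these compounds alone, the earlier steps covered only azepan-1-yl, piperidin-1-yl and 2-methylpyrrolidin-1-yl, so this is the first sign that a urea-bearing group on the saturated ring can be held here without a step beyond the scatter from compound 3, while azepan-1-yl stays apart, with a 6.0-fold lower number from compound 2 to compound 4 (0.78 log units; beyond the scatter). Nothing available explains why the larger group is accepted at this position.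

The compounds shown leave open how much of the result belongs to the five-membered ring and how much to the urea, since a plain pyrrolidin-1-yl or a 3-aminopyrrolidin-1-yl would separate the two. They also leave open how far the group can be extended, for example with a longer chain in place of the methyl on the urea or with a carboxylic acid on the ring.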